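Chloro on the benzyl group of compound 1

The compounds below may be only part of what the source reports. "The series", "measured", "known", "first", "only" and "open" are said of these compounds alone.

Compound 1 `Cc1ccsc1C(=CCCN(C)C(CO)C(=O)NCc1ccccc1)c1sccc1C` gives 6.26 in a single reported number
Compound 2 `Cc1ccsc1C(=CCCN(C)C(CC(C)O)C(=O)NCc1ccccc1)c1sccc1C` gives 5.64; 6.22 (2 entries) over its two entries

Among the measured compounds shown here, in a physicochemical assay for lipophilicity, read by HPLC (on this read-out higher numbers stand for higher lipophilicity and lower numbers for lower lipophilicity), compound 1 has 6.26 as its only number, and a further entry for it gave no single number. The spread that repeated entries can show is seen in the several entries of compound 2 in this assay, 5.64; 6.22 (2 entries) and is worth keeping in mind here. For the measured compounds named here, compound 3 (`Cc1ccsc1C(=CCCN(C)C(CO)C(=O)NCc1ccc(Cl)cc1)c1sccc1C`) differs from compound 1 by chloro in place of hydrogen on an aromatic carbon as its one structural change, with chloro in place of hydrogen on an aromatic carbon, turning benzyl into 4-chlorobenzyl. Going by the values given here, no measured pair shows this change. The expected step in this assay is upward and beyond the scatter, with a number 0.54 log units higher from compound 1 to compound 3 (beyond the scatter) as the estimate resting on the structural change alone. Compound 3 is expected at 6.8 within an estimated range from 6.35 to 7.25 in this measurement.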

Compound 3, partition coefficient: 6.47
Compound 3: middle estimate off by 0.33 log units, on the high side, and the stated range covers the measured number.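

In this assay, among the compounds shown here, this is the first reading of chloro in place of hydrogen on an aromatic carbon, para to a large group, and it gives a number 0.21 log units higher from compound 1 to compound 3 (within the scatter). Turning benzyl into 4-chlorobenzyl therefore does not separate the two compounds on this read-out. Each of the two compounds has only a single number here, and repeated entries in this assay can spread widely, so this one step carries limited weight: the several entries of compound 2 in this assay, 5.64; 6.22 (2 entries)

As far as these compounds go, it remains open whether a methoxy or trifluoromethyl group at this place, or a chloro on another carbon of the same ring, would give a step beyond the scatter from compound 1. From the compounds shown here alone, it is also open whether the same change would read alike on compound 2.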